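The source may hold more compounds than are shown below. What is called first, only, known or untested is meant among the compounds shown, and "the series" means these compounds.

Compound 1: `C=C(Br)C(=O)Nc1cccc(-c2cn3nc(Cc4ccccc4)sc3n2)c1`, 3000 nM
Compound 2: `C=C(Br)C(=O)Nc1cccc(-c2cn3nc(Cc4ccc(Cl)cc4)sc3n2)c1`, 1100 nM
Compound 3: `C=C(Br)C(=O)Nc1cccc(-c2cn3c(-c4ccccc4)csc3n2)c1`, 1300 nM

All three compounds were tested in a functional assay on FM3A cells (Mus musculus) for inhibition, read by cell counting, with a stated time of 2 days; on this read-out higher numbers stand for weaker inhibition and lower numbers for stronger inhibition. In this assay compound 1 gives 3000 nM, compound 2 gives 1100 nM and compound 3 gives 1300 nM.

Compound 1 and compound 2 share the same core and differ in one place only: chloro in place of hydrogen on an aromatic carbon. This change brought a 2.7-fold lower number from compound 1 to compound 2 (0.44 log units; beyond the scatter), a step that lies beyond the usual scatter of the assay.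

Compound 3 carries a different core from compound 1; the difference between the two cores is not broken down here. Its value sits close to that of compound 2, and the two are within the scatter of each other, so no order between them can be read.

Compound 4, `C=C(Br)C(=O)Nc1cccc(-c2cn3c(-c4ccc(Cl)cc4)csc3n2)c1`, has not yet been measured. It stands to compound 3 as compound 2 stands to compound 1: chloro in place of hydrogen on an aromatic carbon. The place of the change is described in the same words for both pairs, so the change is the same one, made on the other core.

Among the measured compounds shown here, for compound 4 the expectation rests on the single earlier example, the step of a 2.7-fold lower number from compound 1 to compound 2 (0.44 log units; beyond the scatter), applied to compound 3 with its value of 1300 nM. For the measured compounds named here, because the only available example is a 2.7-fold lower number from compound 1 to compound 2 (0.44 log units; beyond the scatter) made on a different core, the expected step is taken somewhat more cautiously, as a 2.4-fold lower number from compound 3 to compound 4 (0.37 log units; beyond the scatter). On that basis compound 4 is estimated to give 550 nM in this assay, expected to fall between 200 nM and 1500 nM.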

Compound 4, half-maximal inhibitory concentration: 1100 nM
Compound 4: middle estimate off by 2.0-fold (0.30 log units), on the low side; low and high end bracket the measured number.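

On the second core, the swap from phenyl to 4-chlorophenyl gave a 1.2-fold lower number from compound 3 to compound 4 (0.07 log units; within the scatter) in this assay, so on this core the change has no effect that can be told apart from the ordinary spread of repeated measurements. Set beside the step on the first core, this result does not differ from it by more than the scatter allows: the same change on two cores in this assay, a 2.7-fold lower number (0.44 log units; beyond the scatter) from compound 1 to compound 2 and a 1.2-fold lower number (0.07 log units; within the scatter) from compound 3 to compound 4, 2.3-fold (0.36 log units) apart, within the scatter of two such steps

Among the compounds shown here, this means the data do not show that the change behaves differently on the two cores, but they do not show that it carries over reliably from one to the other either: with only one pair per core, a similar small gain on both cores and a gain on the first core alone both fit the numbers.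

The compounds shown leave open whether a different group on the same aromatic carbon, such as a fluoro, a methoxy group, an amine or a carboxylic acid, would shift the number on either core. They also leave open whether further pairs on these two cores, or on a third one, would make the effect of the chloro group any clearer.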